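A few compounds are considered here, and "the series" means these few. Any claim that something is new, unique, unknown or untested is made for them only; others in the source may bear on it.

Compound 1 `CCO/N=C/c1ccc(OCCC(C)CCN2CCN(c3cccc(N)c3)C2=O)cc1` was tested in an ADME assay on RD cells (Homo sapiens) for cytotoxicity, read by MTT assay, with a stated time of 24 h; on this read-out higher numbers stand for lower toxicity in this test and lower numbers for higher toxicity in this test. In this assay compound 1 reports only a limit of the test, > 100000 nM, and not a number. Compound 2 `CCO/N=C/c1ccc(OCCCCN2CCN(c3ccnc(N)c3)C2=O)cc1` stands beside it in this assay, also at a limit, > 100000 nM. Both results sit at the limit of > 100000 nM in this assay, at which 2 of the 2 values shown sit, so on the numbers shown compound 1 can be placed neither above nor below any other compound; it is simply one of two limit values. Compound 3 `CCO/N=C/c1ccc(OCCC(C)CCN2CCN(c3ccnc(O)c3)C2=O)cc1` has not yet been measured. It differs from compound 1 by 2-hydroxypyridin-4-yl in place of 3-aminophenyl on an amide-type nitrogen in a ring. For the measured compounds named here, no measured step exists in this assay, so no change beyond the scatter is expected in either direction: a number no higher from compound 1 to compound 3 (the limit leaves the size open). For compound 3 the estimate is 100000 nM, with an expected range from 50000 nM to 200000 nM, and the assay is likely to report again only its limit.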

Compound 3, half-maximal cytotoxic concentration: > 100000 nM
Compound 3 gave a limit, no number; the forecaster's own chance of this, stated with the estimate: 80%; the middle value sits exactly at the limit.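

For the compounds shown here, compound 1 and compound 3 both report only a limit in this assay, so no step between them can be read: the limit of > 100000 nM in this assay, at which 3 of the 3 values shown sit. The compounds shown leave open whether 2-hydroxypyridin-4-yl in place of 3-aminophenyl changes the result at all, and in which direction.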